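The compounds below may be only part of what the source reports. "The series", "measured", "known", "first", "only" and "open" are said of these compounds alone.

Compound 3 `O=C(CCCCC#Cc1ccncc1)c1ncc(-c2ccccn2)o1` gives 150 nM in an assay for inhibition of Fatty-acid amide hydrolase 1 (Rattus norvegicus) (a lower number here means a stronger inhibitor, a higher number a weaker inhibitor), the second highest of the three numbers. Compound 1 `O=C(CCCCC#Cc1cccnc1)c1ncc(-c2ccccn2)o1` gives 300 nM; the two numbers lie within the scatter of each other. Compound 2 `O=C(CCCCC#Cc1ccc(Cl)cc1)c1ncc(-c2ccccn2)o1` gives 20 nM; from it, compound 3 stands beyond the scatter. Compound 4 `O=C(CCCCC#Cc1cccc([N+](=O)[O-])c1)c1ncc(-c2ccccn2)o1` differs from compound 3 by 3-nitrophenyl in place of pyridin-4-yl on a triple-bonded carbon. The measured steps that bear on this both exchange a pyridyl for a substituted phenyl: a 7.5-fold higher number from compound 2 to compound 3 (0.88 log units; beyond the scatter), read in reverse, and a 15-fold lower number from compound 1 to compound 2 (1.18 log units; beyond the scatter). A lower number in this assay is therefore expected for compound 4, but since 3-nitrophenyl is not the phenyl that was measured, a smaller step is estimated, a 3.0-fold lower number from compound 3 to compound 4 (0.48 log units; beyond the scatter). Compound 4 is thus expected to give 50 nM, with a range from 15 nM to 200 nM.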

Compound 4, inhibition constant: 4.8 nM
Beside the measured number, compound 4's estimate is 10-fold (1.02 log units) above it; measured number outside the range, below it.
By their numbers in this assay, from the lowest: compound 4; then compound 2; then compounds 3 and 1 (each within the scatter of the next).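

In this assay, 3-nitrophenyl on the triple-bonded carbon improves on both pyridyl compounds (a 31-fold lower number from compound 3 to compound 4 (1.49 log units; beyond the scatter); a 63-fold lower number from compound 1 to compound 4 (1.80 log units; beyond the scatter)). It also improves on the only other substituted phenyl shown (a 4.2-fold lower number from compound 2 to compound 4 (0.62 log units; beyond the scatter)), so the gain seen earlier on leaving a pyridyl for 4-chlorophenyl was not the limit at this place. No evidence given here accounts for this difference.

The step from 4-chlorophenyl to 3-nitrophenyl changes both the group and its numbering on the ring, and the compounds shown do not separate the two. Open too, from the compounds shown here alone, is how 3-chlorophenyl, 4-nitrophenyl or a phenyl carrying an amine would compare.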